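This account rests on a few compounds, and the source may have more. Where it says the series, first, only, none or still open, it means among the compounds named here.

Of the compounds shown here, three have so far been measured in a functional assay on HEK293 cells for agonist activity at Free fatty acid receptor 1 (Homo sapiens), read by fluorescence and calcium flux, with a stated time of 10 min; a lower number here means a smaller maximal response, a higher number a larger maximal response. Compound 1, `COCCOc1ccc2c(c1)OC(COc1ccc(CCC(=O)O)c(F)c1)CC2`, gives 36%. Compound 2, `O=C(O)CCc1ccc(OCC2COc3ccc(Cl)cc3O2)cc1F`, gives 50%. Compound 3, `CCOC(CC(=O)O)c1ccc(OCC2COc3ccc(Cl)cc3O2)cc1`, gives 46%. On these numbers compound 3 lies between the other two: its nearest neighbour is compound 2, whose value sits slightly higher, and its furthest is compound 1, whose value sits somewhat lower. Both gaps fall within the usual scatter of repeated measurements of this kind, so the three compounds cannot be told apart on maximal response.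

Compound 4, `Cn1ccnc1C(CC(=O)O)c1ccc(OCC2COc3ccc(Cl)cc3O2)cc1`, has not yet been measured in this assay. It differs from compound 3 in a single place: 1-methyl-1H-imidazol-2-yl in place of ethoxy on a saturated chain carbon bound to an aromatic carbon and a saturated chain carbon. Among the measured compounds there is no pair that differs only in this way, so no step of this kind can be read from the data, and the expectation for compound 4 rests on the span of the three values alone. For compound 4 the step of a number 1 percentage points lower from compound 3 to compound 4 (within the scatter) is expected to stay within the scatter, with no firm direction. Compound 4 is therefore estimated at 45%, with a range from 25% to 65%.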

Compound 4, largest response reached (Emax), in percent of the reference or control that the assay uses: 68%
Compound 4: the middle estimate sits 23 percentage points below what was measured, and the stated range ends below it.
By their numbers in this assay, from the lowest: compounds 1, 3 and 2 (each within the scatter of the next, the first and the last beyond it); then compound 4.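

In this assay, placing 1-methyl-1H-imidazol-2-yl in place of ethoxy on a saturated chain carbon bound to an aromatic carbon and a saturated chain carbon gives a step of a number 22 percentage points higher from compound 3 to compound 4 (beyond the scatter). For the compounds shown here, the earlier compounds offered no pair differing in one place, so this is the first sign that the group at this carbon can by itself shift the maximal response by more than the usual scatter. It also shows that this carbon can carry a group with one five-membered aromatic ring with 2 hetero atoms, where the ethoxy it replaces has no ring, and that the maximal response rises rather than falls with this exchange. Nothing available here explains the rise.

As far as these compounds go, it remains open whether the gain belongs to any aromatic ring at this carbon or to this particular one, a question that a phenyl, a thiazol-2-yl or an imidazol-2-yl without its methyl group would address. From the compounds shown here alone, it is equally open whether 1-methyl-1H-imidazol-2-yl would give a similar step on the core of compound 1.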